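Aryl amide replaces cinnamide on a shared naphthol core

The source may hold more compounds than are shown below. What is called first, only, known or untested is meant among the compounds shown, and "the series" means these compounds.

Compound 1 `O=C(Nc1cc(Sc2ncn[nH]2)c(O)c2ccccc12)c1cccc([N+](=O)[O-])c1`: 48000 nM
Compound 2 `O=C(/C=C/c1ccccc1)Nc1cc(Sc2ncn[nH]2)c(O)c2ccccc12`: > 100000 nM

Both compounds were tested in a functional assay on MDA-MB-231 cells (Homo sapiens) for antiproliferative activity, read by MTT assay, with a stated time of 48 h; on this read-out higher numbers stand for weaker inhibition and lower numbers for stronger inhibition. Compound 1 gives 48000 nM in this assay. Compound 2 gives only a limit of the assay, > 100000 nM, which is the limit of > 100000 nM in this assay, at which 1 of the 2 values shown sits. Within the data shown here, the change from 2-phenylethenyl to 3-nitrophenyl on the carbonyl carbon is therefore the only measured step: an at least 2.0-fold higher number from compound 1 to compound 2 (0.31 log units; beyond the scatter).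

Compound 3 `COc1ccc(C(=O)Nc2cc(Sc3ncn[nH]3)c(O)c3ccccc23)cc1` is not yet measured. It differs from compound 2 by 4-methoxyphenyl in place of 2-phenylethenyl on a carbonyl carbon. This again exchanges the 2-phenylethenyl group for a six-membered aromatic ring of carbon attached directly to the carbonyl carbon, as in compound 1, so the measured step is the closest guide. Compound 3 is expected to return to the region of compound 1, which means an expected step of an at least 2.0-fold lower number from compound 2 to compound 3 (0.30 log units; that floor lies within the scatter). The estimated value for compound 3 in this assay is 50000 nM, with a range from 20000 nM to 150000 nM.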

Compound 3, half-maximal inhibitory concentration: > 100000 nM
Compound 3 gave a limit, no number; the forecaster's own chance of this, stated with the estimate: 30%; middle value at least 2.0-fold (0.30 log units) away from the limit.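

In this assay, a six-membered aromatic ring on the carbonyl carbon is not enough on its own to give a measurable value: 4-methoxyphenyl in place of 3-nitrophenyl gives an at least 2.0-fold higher number from compound 1 to compound 3 (0.31 log units; beyond the scatter). Among these compounds, then, a measurable result goes with 3-nitrophenyl alone, not with every aromatic ring at this place. Compound 2 and compound 3 both rest at a limit, not a number, so the step between them cannot be read: the limit of > 100000 nM in this assay, at which 2 of the 3 values shown sit.

The 3-nitrophenyl and 4-methoxyphenyl groups differ both in the group carried and in its numbered place on the ring, so the compounds shown do not separate these two changes. Also open, as far as these compounds go, is how an amine or a carboxylic acid on that ring, or a longer chain in its stead, would read in this assay.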